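The source may hold more compounds than are shown below. What is called first, only, known or untested is meant among the compounds shown, and "the series" means these compounds.

Of the compounds shown here, two have been measured in an assay on isolated protein with Bile acid receptor (Homo sapiens) as the target; a higher number here means that more compound is needed for the effect, a lower number that less compound is needed. Compound 1 `COC(=O)/C=C/c1cccc(N(Cc2ccc(/C=C/c3cccc(F)c3)cc2)C(=O)NC(C)C)c1` gives 468 nM, and compound 2 `COC(=O)/C=C/c1cccc(N(Cc2ccc(-c3cccc(Cl)c3)cc2)C(=O)NC(C)C)c1` gives 1410 nM. Compound 2 thus stands at the higher of the two numbers, separated from compound 1 by the step of a 3.0-fold higher number from compound 1 to compound 2 (0.48 log units; beyond the scatter). Compound 3 `COC(=O)/C=C/c1cccc(N(Cc2ccc(-c3cccc(C)c3)cc2)C(=O)NC(C)C)c1` differs from compound 2 only by methyl in place of chloro on an aromatic carbon. Within the data shown here, no measured step shows this exchange: the single step in hand, from compound 1 to compound 2, concerns a different change at that same aromatic carbon and says nothing about trading chloro for methyl. With nothing pointing in either direction, the expected step in this assay is a 1.0-fold lower number from compound 2 to compound 3 (0.00 log units; within the scatter), which is no change beyond the scatter. Compound 3 is accordingly estimated at 1400 nM in this assay, with a range running from 500 nM to 4000 nM.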

Compound 3, half-maximal effective concentration: 1320 nM
Compound 3: the middle estimate sits 1.1-fold (0.03 log units) above what was measured, within the range that was stated.
By their numbers in this assay, from the lowest: compound 1; then compounds 3 and 2 (each within the scatter of the next).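

In this assay methyl in place of chloro on this aromatic carbon gives (a 1.1-fold lower number from compound 2 to compound 3 (0.03 log units; within the scatter)), so at this position the two groups cannot be told apart. The step from the 2-(3-fluorophenyl)ethenyl group to 3-methylphenyl (a 2.8-fold higher number from compound 1 to compound 3 (0.45 log units; beyond the scatter)) shows that the gap first seen with 3-chlorophenyl also appears with a second group on the phenyl ring, and compound 1 keeps the lowest number of the three. No evidence bears on why chloro and methyl read alike here.

On these data alone, whether this tolerance extends to a group of another kind on the same carbon, such as an amine, a carboxylic acid or a methoxy, remains open. Also open is whether the gap to compound 1 follows the ethenyl link or the fluoro, since a directly attached 3-fluorophenyl is not among the compounds shown.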